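This account rests on a few compounds, and the source may have more. Where it says the series, first, only, none or still open, it means among the compounds named here.

In an ADME assay on HEK293 cells (Homo sapiens) for cytotoxicity, read by MTT assay, with a stated time of 48 h (on this read-out lower numbers stand for stronger inhibition and higher numbers for weaker inhibition), three compounds have been measured. Compound 1 `O=C1/C(=C\c2ccc(O)c(O)c2)S/C(=N/c2ccccc2)N1Cc1ccncc1` gives 230000 nM, compound 2 `COc1ccc(/C=C2/S/C(=N/c3ccccc3)N(Cc3ccncc3)C2=O)cc1OC` gives 171000 nM, and compound 3 `CCOc1cc(/C=C2/S/C(=N/c3ccccc3)N(Cc3ccncc3)C2=O)ccc1O` gives 46500 nM, the lowest of the three numbers. The next compound is compound 4 `COc1ccc(OC)c(/C=C2/S/C(=N/c3ccccc3)N(Cc3ccncc3)C2=O)c1`, with 2,5-dimethoxyphenyl in place of 3-ethoxy-4-hydroxyphenyl on a double-bonded chain carbon bound to a double-bonded ring carbon. The closest guide is a 3.7-fold lower number from compound 2 to compound 3 (0.57 log units; beyond the scatter), where 3-ethoxy-4-hydroxyphenyl replaces 3,4-dimethoxyphenyl. By contrast, a 1.3-fold lower number from compound 1 to compound 2 (0.13 log units; within the scatter) shows that one dimethoxyphenyl exchange need not matter, and a 4.9-fold lower number from compound 1 to compound 3 (0.69 log units; beyond the scatter) is similar in size to the closest guide. Reversing the closest guide, a modest rise is expected in this assay. Among the compounds with values here, no measured compound carries 2,5-dimethoxyphenyl, so the range stays wide. The expected step is a 2.6-fold higher number from compound 3 to compound 4 (0.41 log units; beyond the scatter). For compound 4 the estimate is 120000 nM, ranging from 40000 nM to 300000 nM.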

Compound 4, half-maximal inhibitory concentration: 80100 nM
For compound 4 the middle estimate is 1.5-fold (0.18 log units) above the measured one; low and high end bracket the measured number.
By their numbers in this assay, from the lowest: compounds 3 and 4 (each within the scatter of the next); then compounds 2 and 1 (each within the scatter of the next).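

In this assay the exchange of 3-ethoxy-4-hydroxyphenyl for 2,5-dimethoxyphenyl gives a 1.7-fold higher number from compound 3 to compound 4 (0.24 log units; within the scatter) even though the hydrogen-bond donor is lost, so this step stays small. Rearranging the two methoxy groups alone is enough to register, with a 2.1-fold lower number from compound 2 to compound 4 (0.33 log units; beyond the scatter) and, against the 3,4-dihydroxyphenyl ring, a 2.9-fold lower number from compound 1 to compound 4 (0.46 log units; beyond the scatter) as further modest steps. Nothing available explains why these numbers shift. Still open, from the compounds shown here alone, is whether an amine or a carboxylic acid on this ring, or a longer chain in place of methoxy, would move the number further.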